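The source may hold more compounds than are shown below. What is called first, only, known or untested is meant among the compounds shown, and "the series" means these compounds.

Compound 1 `COCC[C@H]1C[C@@H]1c1cncc(N2CCCNCC2)c1` was tested in an assay on a protein complex for displacement of a labelled ligand from Neuronal acetylcholine receptor; alpha2/beta2 (Rattus norvegicus), read by scintillation counting (on this read-out lower numbers stand for stronger inhibition and higher numbers for weaker inhibition), and in that test compound 1 gives 0.3 nM. Compound 2 `COCC[C@@H]1C[C@H]1c1cncc(N2CCCNCC2)c1` is its mirror image; in this assay compound 2 gives 0.3 nM. The step of no change at the digits printed from compound 1 to compound 2 (within the scatter) is therefore flat, and the only thing that separates these two compounds is the fact that compounds 1 and 2 differ only in the configuration as drawn. On the numbers shown, compound 1 thus stands level with compound 2, and nothing in the pair distinguishes one from the other.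

Compound 3 `COCC[C@H]1C[C@@H]1c1cncc(N2CCCN(C)CC2)c1` is the compound still to be measured. Compared with compound 1 it differs by methyl in place of hydrogen on an amine nitrogen in a ring. Among the compounds with values here, the one measured step available, from compound 1 to compound 2, concerns configuration alone and not the amine nitrogen in a ring, so no measured step bears directly on this change. Without such a comparison, the expectation for the step from compound 1 to compound 3 in this assay is a small loss, a 3.3-fold higher number from compound 1 to compound 3 (0.52 log units; beyond the scatter), which stays close to the scatter. Compound 3 is accordingly estimated at 1 nM, with a range from 0.2 nM to 6 nM.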

Compound 3, inhibition constant: 18.1 nM
Compound 3: middle estimate off by 18-fold (1.26 log units), on the low side; measured number above the stated range.
By their numbers in this assay, from the lowest: compounds 1 and 2 (each within the scatter of the next); then compound 3.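

In this assay, methyl in place of hydrogen on an amine nitrogen in a ring gives a 60-fold higher number from compound 1 to compound 3 (1.78 log units; beyond the scatter), so this nitrogen, three ring bonds from the ring atom that bears a large group, is a place where one added carbon has a large effect on the number. The mirror-image pair had shown no change at the digits printed from compound 1 to compound 2 (within the scatter), so across these three compounds inverting both stereocentres leaves the number unmoved, while this single substitution on the nitrogen moves it well beyond the scatter. Within the data shown here, nothing given here explains the size of this step, since the only information available concerns the mirror-image pair and does not bear on the methyl.

On these data alone, whether an ethyl group, a longer chain or an acetyl group on the same nitrogen would give a similar step remains open. Also open, as far as these compounds go, is whether the mirror image of compound 3 would match compound 3 in the way compound 2 matches compound 1, and whether the methyl would have a similar effect on any other receptor.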